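The compounds below may be only part of what the source reports. "The series", "measured", "known", "first", "only" and "open" are said of these compounds alone.

In a functional assay on A549 cells (Homo sapiens) for antiproliferative activity, read by MTT assay, with a stated time of 48 h (a higher number here means a weaker inhibitor, a lower number a stronger inhibitor), compound 2 (`Cc1ccc(/C=C/C(=O)Nc2nnc(-c3ccc(C)cc3)s2)cc1`) gives 1.08 ug/mL as its value and compound 1 (`COc1ccc(-c2nnc(NC(=O)/C=C/c3ccc(C)cc3)s2)cc1`) gives 0.58 ug/mL as its value, so the two stand within the scatter of each other. Compound 3 (`Cc1ccc(-c2nnc(NC(=O)/C=C/c3ccc(F)cc3)s2)cc1`) carries one change from compound 2, fluoro in place of methyl on an aromatic carbon in all. Within the data shown here, only one measured step bears on this, and only indirectly: a 1.9-fold higher number from compound 1 to compound 2 (0.27 log units; within the scatter) for methyl in place of methoxy, at a different substituent, within the scatter. Among the measured compounds shown here, no measured step replaces the methyl in question. Starting from compound 2 at 1.08 ug/mL as the reference, no step beyond the scatter is expected in this assay for this change. The estimated step is a 1.1-fold lower number from compound 2 to compound 3 (0.03 log units; within the scatter) in this expectation. For compound 3 the estimated value is 1 ug/mL, with an expected range of 0.4 ug/mL to 2.5 ug/mL in repeated measurement.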

Compound 3, half-maximal inhibitory concentration: 1.23 ug/mL
Compound 3: the middle estimate sits 1.2-fold (0.09 log units) below what was measured; low and high end bracket the measured number.
By their numbers in this assay, from the lowest: compounds 1, 2 and 3 (each within the scatter of the next, the first and the last beyond it).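

In this assay, the exchange of the 4-methylphenyl for the 4-fluorophenyl gives a 1.1-fold higher number from compound 2 to compound 3 (0.06 log units; within the scatter), so at this position the two groups cannot be told apart. Among these compounds, the earlier step concerned a different substituent, whereas this one gives the first reading at this position, with the methyl on the other aromatic ring kept in place. No measurement available here bears on the reason for this result.

Going by these compounds, what remains open is whether this position stays as flat with a group of a different kind, such as an amine, a carboxylic acid or a longer chain. On these data alone, it is also open whether fluoro in place of methyl gives a similar step when the methoxy of compound 1 is present on the other side.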